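A few compounds are considered here, and "the series" means these few. Any claim that something is new, unique, unknown or untested is made for them only; others in the source may bear on it.

Measured compounds in a functional assay on IMR-32 cells (Homo sapiens) for cytotoxicity, read by sulforhodamine B assay, with a stated time of 48 h; a lower number here means a stronger inhibitor, a higher number a weaker inhibitor:
compound 1 `O=CCN1N=C(c2ccc3ccccc3c2)CC1c1ccccc1` gives 10000 nM
compound 2 `COc1ccc(C2CC(c3ccc4ccccc4c3)=NN2CC=O)c(OC)c1OC` gives 780 nM
compound 3 `COc1ccc(C2CC(c3ccc4ccccc4c3)=NN2CC=O)cc1OC` gives 1590 nM

Compound 3 stands second highest of the three numbers. The nearest gap is the step of a 2.0-fold higher number from compound 2 to compound 3 (0.31 log units; beyond the scatter), which lies beyond the scatter. The furthest number is that of compound 1, the highest of the set.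

Compound 4 `COc1ccc(C2CC(c3ccc4ccccc4c3)=NN2CC=O)cc1` is not yet measured. It differs from compound 3 in one place: hydrogen in place of methoxy on an aromatic carbon. Within the data shown here, the only measured step of the same kind is a 2.0-fold higher number from compound 2 to compound 3 (0.31 log units; beyond the scatter), a modest rise in the number when a methoxy group is replaced by hydrogen on an aromatic carbon. On that basis a further rise of similar size is expected in this assay, though a single precedent leaves the size uncertain and a step within the scatter cannot be excluded. The expected step of a 1.9-fold higher number from compound 3 to compound 4 (0.28 log units; within the scatter) points toward a weaker inhibitor. Compound 4 is therefore estimated at 3000 nM, with a range from 1200 nM to 8000 nM.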

Compound 4, half-maximal inhibitory concentration: 4120 nM
Beside the measured number, compound 4's estimate is 1.4-fold (0.14 log units) below it; the measured number falls inside the stated range.
By their numbers in this assay, from the lowest: compound 2; then compound 3; then compound 4; then compound 1.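

In this assay, the methoxy of compound 3 that lies ortho to a methoxy group and meta to a large group also counts, with a 2.6-fold higher number from compound 3 to compound 4 (0.41 log units; beyond the scatter). The remaining methoxy counts as well, with a 2.4-fold lower number from compound 1 to compound 4 (0.39 log units; beyond the scatter), so all the single methoxy-for-hydrogen steps among these four compounds run the same way and none goes against them. The size of the change also reads alike on two cores: the same change on two cores in this assay, a 2.0-fold higher number (0.31 log units; beyond the scatter) from compound 2 to compound 3 and a 2.4-fold higher number (0.39 log units; beyond the scatter) from compound 4 to compound 1, 1.2-fold (0.08 log units) apart, within the scatter of two such steps.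

On these data alone, these steps cover only methoxy and hydrogen on this ring, so whether a hydroxyl, an ethoxy or an amine in the same place would follow them stays open. Also open, as far as these compounds go, is how a single methoxy would read elsewhere on the ring, and whether the same steps hold outside this one cell line.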